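The source may report more compounds than this note shows. Statements on the series, on what has been measured and on what is new or still open speak of the compounds shown alone.

Measured so far:
compound 1 `COc1ccc(-c2cc(/C=C/C(=O)c3ccc(N)cc3)[nH]n2)cc1` — -35%
compound 2 `COc1cc(-c2cc(/C=C/C(=O)c3ccc(N)cc3)[nH]n2)cc(OC)c1OC` — -35%

In a functional assay on RPMI-8226 cells (Homo sapiens) for cytotoxicity, read by sulforhodamine B assay, with a stated time of 48 h, tested at 10 uM (on this read-out higher numbers stand for a weaker effect at the one concentration tested and lower numbers for a stronger effect), compound 1 gives -35%. In this assay compound 2 gives -35%, level with compound 1 at the digits reported and within the usual scatter. Among the compounds with values here, compound 1 and compound 2 differ in more than one place, so no single step is computed between them; their two values simply read the same.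

Compound 3 `COc1ccc(-c2cc(/C=C/C(=O)c3ccc(N)cc3)[nH]n2)cc1OC` is not yet measured in this assay. It differs from compound 2 by one change: hydrogen in place of methoxy on an aromatic carbon. Within the data shown here, no step of this kind between measured compounds exists, so the expectation rests on the two values at hand, -35% for compound 1 and -35% for compound 2, which sit at one level. The step from compound 2 to compound 3 is therefore expected to be none beyond the scatter, in either direction. For compound 3 the estimate in this assay is -35%, with a range from -55% to -15%. The estimated step of no change at the digits printed from compound 2 to compound 3 (within the scatter) is expected to stay within the scatter.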

Compound 3, a percentage reported as activity, at one concentration (the size of the read-out at that concentration, not a potency): -20%
Estimate against measurement, compound 3: 15 percentage points below; the measured number falls inside the stated range.
By their numbers in this assay, from the lowest: compounds 1 and 2 (each within the scatter of the next); then compound 3.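

Hydrogen in place of methoxy on this aromatic carbon gives a number 15 percentage points higher from compound 2 to compound 3 (beyond the scatter) in this assay, so this position can move the read-out, and the move is toward a weaker effect. Methoxy in place of hydrogen gives a number 15 percentage points higher from compound 1 to compound 3 (beyond the scatter) in the same assay, also toward a weaker effect, so the number of methoxy groups alone does not order the three compounds: compound 3, with neither the fewest nor the most, has the weakest effect. Nothing available here accounts for this reversal.

Open, from the compounds shown here alone, is how a hydroxyl, a chlorine or an ethoxy group on this aromatic carbon would read. Also open, going by these compounds, is whether the same pattern holds when the amine on the other aromatic ring is replaced by another group.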